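Dropping the dimethylamino group from compound 3

A few compounds are considered here, and "the series" means these few. Any claim that something is new, unique, unknown or untested is made for them only; others in the source may bear on it.

In a functional assay on CAL-27 cells (Homo sapiens) for cytotoxicity, read by MTT assay, with a stated time of 72 h (a higher number here means a weaker inhibitor, a lower number a stronger inhibitor), compound 1 (`O=C(CCCCCN(CC(=O)NC1CCCCC1)C(=O)c1ccccc1)NO`) gives 3800 nM and compound 2 (`O=C(CCCCCN(CC(=O)NC1CCCCC1)C(=O)c1cccc2ccccc12)NO`) gives 2400 nM in the same test. Compound 3 (`CN(C)c1ccc(C(=O)N(CCCCCC(=O)NO)C(C)(C)C(=O)NC2CCCCC2)cc1`) gives 47700 nM as the highest of the three numbers, and its distance from each of the other two lies beyond the scatter.

Compound 4 (`CC(C)(C(=O)NC1CCCCC1)N(CCCCCC(=O)NO)C(=O)c1ccccc1`) differs from compound 3 in one place, with hydrogen in place of dimethylamino on an aromatic carbon, para to a large group (hydrogen in place of dimethylamino on an aromatic carbon) so that 4-(dimethylamino)phenyl becomes phenyl. Going by the values given here, one measured step bears on this, since it also swaps the aromatic group on a carbonyl carbon. Naphthalen-1-yl in place of phenyl gives a 1.6-fold lower number from compound 1 to compound 2 (0.20 log units; within the scatter) and so stays within the scatter. Among the compounds with values here, no measured step removes a dimethylamino group, so this support is indirect, and the data do not show how much of the high number of compound 3 goes with that group.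

A modest move toward a lower number is therefore expected in this assay and it may not clear the scatter. The expected change is a 1.9-fold lower number from compound 3 to compound 4 (0.28 log units; within the scatter) as a central figure. The estimate for compound 4 is 25000 nM with an expected range from 8000 nM to 60000 nM as its lower and upper ends.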

Compound 4, half-maximal inhibitory concentration: 66900 nM
Compound 4: middle estimate off by 2.7-fold (0.43 log units), on the low side, and the stated range ends below it.
By their numbers in this assay, from the lowest: compounds 2 and 1 (each within the scatter of the next); then compounds 3 and 4 (each within the scatter of the next).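

In this assay, putting hydrogen in place of dimethylamino on an aromatic carbon, para to a large group, gives a 1.4-fold higher number from compound 3 to compound 4 (0.15 log units; within the scatter) and so leaves 4-(dimethylamino)phenyl and phenyl indistinguishable at this position. Going by these compounds alone, this is the first direct reading of the change, since the earlier step only swapped phenyl for naphthalen-1-yl on the core of compound 1, and it shows that the high number of compound 3 does not depend on the dimethylamino group: compound 4, which lacks that group, gives 66900 nM in the same test. No measurement among the compounds shown offers an explanation for why the two numbers stay within the scatter of each other.

Only hydrogen and dimethylamino are shown at this place, so it remains open whether a methoxy group, a fluorine atom or a carboxylic acid there would stay within the scatter of these two compounds. Going by these compounds, it also remains open whether naphthalen-1-yl in place of phenyl would give a step of similar size on the core of compound 4 as on the core of compound 1.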